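Aryl exchange on the shared core: toward compound 3

This account rests on a few compounds, and the source may have more. Where it says the series, first, only, none or still open, it means among the compounds named here.

Measured so far in an assay on CHO cells for displacement of a labelled ligand from adenosine receptor A3 (Homo sapiens), read by scintillation counting, tested at 10 uM; a lower number here means less inhibition, a higher number more inhibition at the concentration tested (going by the name of the read-out):
compound 1 `CC(C)(C)Cc1c(-c2c(F)cccc2F)sc(N)c1C(=O)c1ccc(Cl)cc1`, inhibition 1%
compound 2 `COc1ccc(-c2sc(N)c(C(=O)c3ccc(Cl)cc3)c2CC(C)(C)C)cc1`, inhibition 2%

Compound 2 holds the higher of the two numbers in this assay, with compound 1 the nearest, and the gap between them is within the scatter. Within the data shown here, the only step measured so far, a number 1 percentage points higher from compound 1 to compound 2 (within the scatter), shows that swapping one six-membered aryl group for another at this position left the read-out where it was.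

Compound 3 `Cc1noc(C)c1-c1sc(N)c(C(=O)c2ccc(Cl)cc2)c1CC(C)(C)C` differs from compound 2 as follows: 3,5-dimethyl-1,2-oxazol-4-yl in place of 4-methoxyphenyl on an aromatic carbon. Among the measured compounds shown here, no step with a five-membered ring at this position has been measured, so the expectation rests on the one step above, which was within the scatter. The same is expected here: a step of no change at the digits printed from compound 2 to compound 3 (within the scatter), none beyond the scatter. Compound 3 is therefore estimated at 2% in this assay, within -8% to 12%.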

Compound 3, a percentage reported as inhibition, at one concentration (the size of the read-out at that concentration, not a potency): 1%
Estimate against measurement, compound 3: 1 percentage points above; the measured number falls inside the stated range.
By their numbers in this assay, from the lowest: compounds 1, 3 and 2 (each within the scatter of the next).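

In this assay the change to 3,5-dimethyl-1,2-oxazol-4-yl gives a number 1 percentage points lower from compound 2 to compound 3 (within the scatter) and also no change at the digits printed from compound 1 to compound 3 (within the scatter) as its second reading. The insensitivity seen between two six-membered aromatic rings of carbon therefore also holds for a five-membered aromatic ring with 2 hetero atoms at this carbon next to the ring sulfur, so the three aryl groups are not told apart by this read-out at the concentration tested. No evidence is at hand that bears on this result.

Still open, as far as these compounds go, is whether any group at this carbon separates from these three, for example a carboxylic acid or an aminomethyl group. From the compounds shown here alone, with neopentyl and the (4-chlorophenyl)carbonyl group common to all three compounds, it is also open whether a longer chain in place of neopentyl, or another group in place of the (4-chlorophenyl)carbonyl group, would shift the read-out.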